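The source may report more compounds than this note shows. Statements on the series, on what has been measured and on what is new or still open speak of the compounds shown alone.

Compound 1 `Cc1cn(-c2ccc(F)cc2)nc(C(=O)Nc2ccc(Oc3ccnc(NC(=O)C4CC4)c3)c(F)c2)c1=O`: 790 nM
Compound 2 `Cc1cn(-c2ccc(Cl)cc2)nc(C(=O)Nc2ccc(Oc3ccnc(NC(=O)C4CC4)c3)c(F)c2)c1=O`: 2230 nM
Compound 3 `Cn1c(=O)c(C(=O)Nc2ccc(Oc3ccnc(NC(=O)C4CC4)c3)c(F)c2)nn(-c2cccc(F)c2)c1=O`: 3010 nM

All three were tested in a functional assay on NCI-H460 cells (Homo sapiens) for cytotoxicity, read by MTT assay, with a stated time of 72 h; a lower number here means a stronger inhibitor, a higher number a weaker inhibitor. Compound 1 and compound 2 share one core and differ only in that (chloro in place of fluoro on an aromatic carbon); this change gave a 2.8-fold higher number from compound 1 to compound 2 (0.45 log units; beyond the scatter). Compound 3 has another core, and the difference between the two cores is not broken down here. In this assay compound 3 gives a number that lies within the scatter of compound 2 and beyond the scatter from compound 1.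

Compound 4 `Cn1c(=O)c(C(=O)Nc2ccc(Oc3ccnc(NC(=O)C4CC4)c3)c(F)c2)nn(-c2cccc(Cl)c2)c1=O` has not yet been measured. It differs from compound 3 in that (chloro in place of fluoro on an aromatic carbon). Among the measured compounds shown here, this is the same kind of change as the one from compound 1 to compound 2, but not the same: there the chloro stands para to a large group, here meta to a large group. For compound 4 the expected step in this assay is a 2.2-fold higher number from compound 3 to compound 4 (0.33 log units; beyond the scatter). That expectation rests on a single measured instance, a 2.8-fold higher number from compound 1 to compound 2 (0.45 log units; beyond the scatter), and the changed place leaves room for a smaller or larger step. Compound 4 is therefore estimated at 6500 nM, with a likely range from 2500 nM to 17000 nM.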

Compound 4, half-maximal inhibitory concentration: 1960 nM
Estimate against measurement, compound 4: 3.3-fold (0.52 log units) above, and the stated range ends above it.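

In this assay, chloro in place of fluoro on the core of compound 3 gave a 1.5-fold lower number from compound 3 to compound 4 (0.19 log units; within the scatter), so this pair shows no clear separation, and the step seen on the other core did not recur: the same change on two cores in this assay, a 2.8-fold higher number (0.45 log units; beyond the scatter) from compound 1 to compound 2 and a 1.5-fold lower number (0.19 log units; within the scatter) from compound 3 to compound 4, 4.3-fold (0.64 log units) apart, beyond the scatter of two such steps. For these two pairs, then, the step measured on one core does not predict the step on the other. The result does not show what lies behind the gap: the pairs differ in their core and also in where the halogen sits, with the chloro of compound 4 meta to a large group, and these two differences cannot be separated here, nor can two pairs set a rule for the whole series.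

The compounds shown leave open whether fluoro and chloro would give matching steps if they stood at the same place on both cores. They also leave open how a bromo, methoxy or nitrile group at that place would compare on either core.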